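This account rests on a few compounds, and the source may have more. Where it says the series, first, only, none or still open, it means among the compounds named here.

Measured compounds:
compound 1 `COc1ccc(Oc2ccc3c(NCCCNCc4cc(F)ccc4OC)ccnc3c2)cc1` 14500 nM
compound 2 `Clc1ccc(Oc2ccc3c(NCCCNCc4ccco4)ccnc3c2)cc1` 14500 nM
compound 3 `COc1ccc(Oc2ccc3c(NCCCNCc4cccc(OC)c4O)ccnc3c2)cc1` 14500 nM

In a physicochemical assay for solubility, with a stated time of 18 h, at pH 7.4 (on this read-out lower numbers stand for lower solubility and higher numbers for higher solubility), compound 1 stands level with compound 2 and compound 3. For the measured compounds named here, the one measured step, no change at the digits printed from compound 1 to compound 3 (within the scatter), exchanged the aryl group on a saturated chain carbon bound to an amine nitrogen and left this assay unmoved within scatter. Compound 4 `COc1ccc(F)cc1CNCCCNc1ccnc2cc(Cc3cccc(C(F)(F)F)c3)ccc12` differs from compound 1 at another place: 3-(trifluoromethyl)benzyl in place of 4-methoxyphenoxy on an aromatic carbon. Going by the values given here, no measured step touches that aromatic carbon, so nothing measured bears directly on this change; the known step only shows the read-out insensitive to a change elsewhere. Without precedent, a moderate fall in this assay is expected, with a wide range. Compound 4 is estimated at 5000 nM, between 1000 nM and 15000 nM, an expected step of a 2.9-fold lower number from compound 1 to compound 4 (0.46 log units; beyond the scatter).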

Compound 4, solubility: 4200 nM
For compound 4 the middle estimate is 1.2-fold (0.08 log units) above the measured one; low and high end bracket the measured number.
By their numbers in this assay, from the lowest: compound 4; then compounds 1, 2 and 3 (each within the scatter of the next).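

In this assay, for the compounds shown here, the aromatic carbon carrying 4-methoxyphenoxy in compound 1 is the first position seen to move the read-out: 3-(trifluoromethyl)benzyl in its place gives a 3.5-fold lower number from compound 1 to compound 4 (0.54 log units; beyond the scatter). The change replaces the link to the ring and the ring's substituent at once, and this single step does not separate the two. Open, as far as these compounds go, is whether 4-methoxybenzyl or 3-(trifluoromethyl)phenoxy at this carbon would stand nearer compound 1 or compound 4, and how a morpholine or a carboxylic acid there would read. No measurement at hand gives a reason for the step.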